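This account rests on a few compounds, and the source may have more. Where it says the series, first, only, none or still open, it means among the compounds named here.

Of the compounds shown here, two of this set have been tested so far in an ADME assay on microsomes from liver (Rattus norvegicus) for metabolic stability, with a stated time of 10 min; a lower number here means that less of the compound is left, a higher number that more of the compound is left. Among the compounds with values here, compound 1 `CC(C)S(=O)(=O)NC(=O)c1ccc(Nc2nc(NC3(c4ccc(Cl)cc4)CC3)nc(OCC(F)(F)F)n2)cc1` gives 96% in this assay, the lower of the two numbers at hand, though its only neighbour sits close by. Compound 2 `CC(=O)NCCS(=O)(=O)NC(=O)c1ccc(Nc2nc(NC3(c4ccc(Cl)cc4)CC3)nc(OCC(F)(F)F)n2)cc1` gives 100% in this assay. Within the data shown here, the single step between measured compounds, a number 4 percentage points higher from compound 1 to compound 2 (within the scatter), replaces the isopropyl on the sulfonyl sulfur with a 2-acetamidoethyl and stays within the scatter.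

Compound 3 `CNC(=O)NCCS(=O)(=O)NC(=O)c1ccc(Nc2nc(NC3(c4ccc(Cl)cc4)CC3)nc(OCC(F)(F)F)n2)cc1` has not yet been measured. It differs from compound 1 in one place: 2-((methylcarbamoyl)amino)ethyl in place of isopropyl on a sulfonyl sulfur. Among the measured compounds shown here, the entering chain and the 2-acetamidoethyl of compound 2 both sit on the same sulfonyl sulfur, so the step from compound 1 to compound 2 is the one comparison that bears on this change. Because compound 1 already gives 96% near the top of the scale, and because the step of a number 4 percentage points higher from compound 1 to compound 2 (within the scatter) stayed within the scatter, compound 3 is expected to move by a number 1 percentage points higher from compound 1 to compound 3 (within the scatter), which is no change beyond the scatter. Compound 3 is thus estimated to show 97%, within a range from 90% to 100%.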

Compound 3, percent of the compound remaining: 100%
Compound 3: middle estimate off by 3 percentage points, on the low side; the range from low to high includes it.
By their numbers in this assay, from the lowest: compounds 1, 2 and 3 (each within the scatter of the next).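

In this assay, the sulfonyl sulfur now carries a second long chain with no change beyond the scatter: 2-((methylcarbamoyl)amino)ethyl in place of isopropyl gives a number 4 percentage points higher from compound 1 to compound 3 (within the scatter). The new comparison is within the chain itself, where methylamino in place of methyl on a carbonyl carbon gives no change at the digits printed from compound 2 to compound 3 (within the scatter), so this read-out does not separate the two chains that differ at that carbonyl carbon. No measurement at hand explains why the read-out stays the same across these changes.

On these data alone, whether an amine, a carboxylic acid or a longer chain on the same sulfonyl sulfur would leave the read-out just as undisturbed remains open, since the three groups seen here give numbers within the scatter of each other. Also open is how much of the result comes from the shared core rather than from the group on the sulfonyl sulfur, and whether differences among these compounds would appear under conditions that leave less of the compound remaining.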